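The source may hold more compounds than are shown below. What is called first, only, known or untested is meant among the compounds shown, and "the series" means these compounds.

Compound 1 `COc1ccc(/C=C/C2CC=CC(=O)O2)cc1`: 28.3 uM
Compound 2 `COc1ccc(/C=C/C2CC=CC(=O)O2)cc1OC`: 14.6 uM

Going by the values given here, in a functional assay on NCI-H460 cells (Homo sapiens) for inhibition, read by sulforhodamine B assay, with a stated time of 48 h (on this read-out lower numbers stand for stronger inhibition of growth and higher numbers for weaker inhibition of growth), compound 2 stands at the lower of the two numbers, with compound 1 as its only neighbour. Among the compounds with values here, the single measured step, a 1.9-fold lower number from compound 1 to compound 2 (0.29 log units; within the scatter), was the same kind of change now made again. Compound 3 `COc1cc(/C=C/C2CC=CC(=O)O2)cc(OC)c1OC` differs from compound 2 by methoxy in place of hydrogen on an aromatic carbon. Because that earlier step a 1.9-fold lower number from compound 1 to compound 2 (0.29 log units; within the scatter) stayed within the scatter, no step beyond the scatter is expected here, and the estimated shift is a 1.3-fold lower number from compound 2 to compound 3 (0.12 log units; within the scatter). Compound 3 is therefore expected to give about 11 uM, with a range from 4 uM to 30 uM.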

Compound 3, concentration for growth inhibition (reported as GI): 28.8 uM
Estimate against measurement, compound 3: 2.6-fold (0.42 log units) below; low and high end bracket the measured number.
By their numbers in this assay, from the lowest: compounds 2, 1 and 3 (each within the scatter of the next).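

In this assay, methoxy in place of hydrogen on this further aromatic carbon, ortho to a methoxy group, gives a 2.0-fold higher number from compound 2 to compound 3 (0.30 log units; within the scatter). This second step of the same kind also stays within the scatter, so neither methoxy change shown here can be told apart from repeat-measurement noise. No measurement at hand bears on the reason for this result. The compounds shown leave open whether a hydroxyl, an amine or a longer chain such as ethoxy on this carbon would give a step beyond the scatter.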